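Swapping propylsulfanyl for allylsulfanyl on the shared core

The source may report more compounds than this note shows. Statements on the series, on what has been measured and on what is new or still open speak of the compounds shown alone.

compound 1 `C=CCOC(=O)C1=C2C(=NC1=O)c1cccc3c(SCCC)ccc2c13`: 13100 nM
compound 2 `CCCSc1ccc2c3c(cccc13)C1=NC(=O)C(C(=O)OCC)=C12`: 1700 nM

Among the compounds with values here, in a functional assay on T-24 cells (Homo sapiens) for antiproliferative activity, read by sulforhodamine B assay, with a stated time of 72 h (on this read-out higher numbers stand for weaker inhibition and lower numbers for stronger inhibition), compound 2 gives 1700 nM, the lower of the two numbers so far and therefore the stronger inhibition. The next compound to be tested, compound 3 `C=CCSc1ccc2c3c(cccc13)C1=NC(=O)C(C(=O)OCC)=C12`, differs from compound 2 in one place: vinyl in place of ethyl on a saturated chain carbon bound to a sulfur. In words, this is vinyl in place of ethyl on a saturated chain carbon bound to a sulfur, so propylsulfanyl becomes allylsulfanyl.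

Within the data shown here, only one measured step bears on this change: a 7.7-fold lower number from compound 1 to compound 2 (0.89 log units; beyond the scatter). That step removed a vinyl at a different place on the molecule, so it is only a loose guide and says nothing direct about the chain on sulfur. Adding a vinyl here is therefore expected to push the number up, but by less than that step, and perhaps not beyond the scatter. In this assay the estimated change is a 1.5-fold higher number from compound 2 to compound 3 (0.18 log units; within the scatter). For compound 3 the expected value is 2600 nM, with an estimated range of 800 nM to 8500 nM.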

Compound 3, half-maximal inhibitory concentration: 700 nM
Beside the measured number, compound 3's estimate is 3.7-fold (0.57 log units) above it, outside the stated range (below it).
By their numbers in this assay, from the lowest: compound 3; then compound 2; then compound 1.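

In this assay, the chain on sulfur proves sensitive to a small edit: vinyl in place of ethyl on a saturated chain carbon bound to a sulfur gives a 2.4-fold lower number from compound 2 to compound 3 (0.39 log units; beyond the scatter), a gain in inhibition beyond the scatter. The swap leaves the count at 2 heavy atoms and adds 1 double bond outside aromatic rings, so a small change in the group, with no added size by that count, is enough to move the number. The earlier step, a 7.7-fold lower number from compound 1 to compound 2 (0.89 log units; beyond the scatter), removed a vinyl at a different place and also lowered the number, so across these compounds a vinyl goes with weaker inhibition on the chain bound to oxygen and stronger inhibition on the chain bound to sulfur, and no measurement at hand explains that contrast.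

As far as these compounds go, how a longer chain such as butyl, or a benzyl group, would compare with allylsulfanyl on the sulfur remains open. So does whether the gain from allylsulfanyl would hold with a carboxylic acid in place of the ethyl ester on the shared core.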